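The source may report more compounds than this note shows. Statements on the series, on what has been measured and on what is new or still open speak of the compounds shown alone.

In an assay for inhibition of Indoleamine 2,3-dioxygenase 1 (Homo sapiens), with stated times of 10 min and 60 min (on this read-out higher numbers stand for weaker inhibition and lower numbers for stronger inhibition), compound 1 `N#Cc1cc(NCc2ccccc2[N+](=O)[O-])c2cn[nH]c2c1` reaches only the limit of the assay, > 100000 nM. Compound 2 `COC(=O)c1cc(NCc2ccccc2[N+](=O)[O-])c2cn[nH]c2c1` likewise gives only the limit > 100000 nM in this assay. The step that the two limits leave unreadable from compound 1 to compound 2 stays unreadable since (the limit of > 100000 nM in this assay, at which 2 of the 2 values shown sit). Compound 3 `O=[N+]([O-])c1ccccc1CNc1cc(Br)cc2[nH]ncc12` differs from compound 2 by bromo in place of methoxycarbonyl on an aromatic carbon. Within the data shown here, no measured step bears on this change, so no shift beyond the scatter can be read in either direction, and the expected step is a number no higher from compound 2 to compound 3 (the limit leaves the size open). Compound 3 is therefore estimated at 100000 nM, within a range from 20000 nM to 300000 nM, most probably again only a limit.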

Compound 3, half-maximal inhibitory concentration: 8040 nM
Compound 3: middle estimate off by 12-fold (1.09 log units), on the high side; measured number below the stated range.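

In this assay, the group on this aromatic carbon decides whether a number can be read at all. Bromo in place of methoxycarbonyl gives an at least 12-fold lower number from compound 2 to compound 3 (1.09 log units; beyond the scatter), and bromo in place of cyano gives an at least 12-fold lower number from compound 1 to compound 3 (1.09 log units; beyond the scatter), while the step between compound 1 and compound 2 cannot be read. The true sizes of both readable steps stay open, as each starts from a compound at the limit: the limit of > 100000 nM in this assay, at which 2 of the 3 values shown sit.

From the compounds shown here alone, what remains open is whether bromo is special here or whether chloro, an amine or a carboxylic acid at this place would give a similar number.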